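The source may hold more compounds than are shown below. What is called first, only, known or untested is meant among the compounds shown, and "the series" means these compounds.

Compound 2 `CCCc1nc2cc(-c3nc4cc(-c5nc6cc(-c7ccccc7)ccc6[nH]5)ccc4[nH]3)ccc2[nH]1` carries a propyl group on the shared core and, in a functional assay on RPMI 8402 cells (Homo sapiens) for cytotoxicity (a lower number here means a stronger inhibitor, a higher number a weaker inhibitor), compound 2 gives 60 nM. It stands level with compound 1 `CC(C)c1nc2cc(-c3nc4cc(-c5nc6cc(-c7ccccc7)ccc6[nH]5)ccc4[nH]3)ccc2[nH]1`, which carries isopropyl in place of that propyl and in this assay gives 60 nM; the step of no change at the digits printed from compound 1 to compound 2 (within the scatter) lies within the scatter. Compound 3 `c1ccc(-c2ccc3[nH]c(-c4ccc5[nH]c(-c6ccc7[nH]c(-c8ccccc8)nc7c6)nc5c4)nc3c2)cc1` differs from compound 2 by phenyl in place of propyl on an aromatic carbon. For the measured compounds named here, only one measured step bears on this change, the exchange of isopropyl for propyl, and it was flat; no measured pair shows an aromatic ring entering here. A chain giving way to a ring is a larger change than that step, so the footing is thin, but with nothing pointing either way the expected step of no change at the digits printed from compound 2 to compound 3 (within the scatter) is none beyond the scatter, with a wide range for the untested kind of change. Compound 3 is therefore estimated at 60 nM, between 20 nM and 200 nM.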

Compound 3, half-maximal inhibitory concentration: 60 nM
For compound 3 middle estimate and measured number coincide at the digits printed; measured number inside the range.
By their numbers in this assay, from the lowest: compounds 1, 2 and 3 (each within the scatter of the next).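

For the compounds shown here, at this position, on an aromatic carbon of a five-membered aromatic ring with 2 nitrogen, the earlier compounds showed only one open chain exchanged for another. Here a six-membered aromatic ring of carbon only stands in that place, and in this assay phenyl in place of propyl gives no change at the digits printed from compound 2 to compound 3 (within the scatter), while phenyl in place of isopropyl gives no change at the digits printed from compound 1 to compound 3 (within the scatter), so across these three compounds the read-out does not separate a ring from a chain, even with 6 heavy atoms entering where 3 left. No measurement available here accounts for this flat result.

All three groups shown are carbon only. From the compounds shown here alone, whether an amine, a carboxylic acid, a longer chain or a substituted phenyl at this place would leave the value level remains open.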